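This account rests on a few compounds, and the source may have more. Where it says the series, first, only, none or still open, it means among the compounds named here.

Going by the values given here, in a functional assay on MIA PaCa-2 cells (Homo sapiens) for inhibition, read by MTT assay, with a stated time of 7 days (a higher number here means a weaker inhibitor, a lower number a stronger inhibitor), compound 1 `CCN(CC)S(=O)(=O)c1ccc(S(=O)(=O)N2CCC[C@@H](C(=O)N[C@H]3CC[C@H](OC)CC3)C2)cc1` gives 1350 nM, the highest of the three numbers so far. Compound 4 `CCN(CC)S(=O)(=O)c1ccc(S(=O)(=O)N2CCC[C@@H](C(=O)N3CCC(COC)CC3)C2)cc1` is not yet measured and differs from compound 1 by 4-(methoxymethyl)piperidin-1-yl in place of (4-methoxycyclohexyl)amino on a carbonyl carbon. Among the compounds with values here, the only measured step, a 2.4-fold higher number from compound 2 to compound 3 (0.37 log units; beyond the scatter), is modest and lies at a sulfonyl sulfur, not on the carbonyl carbon, so it sets no size for this change. Compound 2 `CC(C)S(=O)(=O)c1ccc(S(=O)(=O)N2CCC[C@@H](C(=O)N3CCC(F)(F)CC3)C2)cc1` at 11 nM and compound 3 `O=C([C@@H]1CCCN(S(=O)(=O)c2ccc(S(=O)(=O)C3CC3)cc2)C1)N1CCC(F)(F)CC1` at 26 nM also carry no amide hydrogen, but they differ from compound 1 in other places too, so this is weak support for a lower number. The expected change is a 5.4-fold lower number from compound 1 to compound 4 (0.73 log units; beyond the scatter), with wide uncertainty. For compound 4 the estimate is 250 nM, with an expected range of 40 nM to 1300 nM.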

Compound 4, half-maximal inhibitory concentration: 250 nM
For compound 4 middle estimate and measured number coincide at the digits printed, and the stated range covers the measured number.
By their numbers in this assay, from the lowest: compound 2; then compound 3; then compound 4; then compound 1.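

In this assay, the carbonyl carbon now has a measured step of its own, a 5.4-fold lower number from compound 1 to compound 4 (0.73 log units; beyond the scatter), whereas the earlier step lay on a sulfonyl sulfur. The change keeps the same atoms and loses the amide hydrogen, but this single pair cannot separate that loss from the other differences between the two groups. No measured evidence bears on the cause of this step. Still open, from the compounds shown here alone, is how a 4-hydroxypiperidin-1-yl or 4-carboxypiperidin-1-yl group would read on this carbonyl carbon, and whether a methyl on the amide nitrogen of compound 1 would give a step of similar size.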